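The source may report more compounds than this note shows. Statements on the series, on what has been measured and on what is new or still open speak of the compounds shown alone.

Measured compounds:
compound 1 `O=C(Nc1ccc(O)c(Sc2nncs2)c1)c1ccc([N+](=O)[O-])cc1`: "not active" (no number reported)
compound 2 `O=[N+]([O-])c1ccc(S(=O)(=O)Nc2ccc(O)c(Sc3ncnc4nc[nH]c34)c2)cc1`: 37.5%
compound 3 `O=[N+]([O-])c1ccc(S(=O)(=O)Nc2ccc(O)c(Sc3nncs3)c2)cc1`: 14.9%

In an assay on isolated protein for inhibition of RAC-alpha serine/threonine-protein kinase (Homo sapiens), read by fluorescence, with a stated time of 30 min, tested at 10 uM (on this read-out lower numbers stand for less inhibition and higher numbers for more inhibition at the one concentration tested (going by the name of the read-out)), compound 1 is recorded as "not active" (no number reported), with no number attached, so it stands at the bottom of this set without a figure. Compound 2 gives 37.5% and compound 3 gives 14.9%; the step of a number 22.6 percentage points lower from compound 2 to compound 3 (beyond the scatter). Compound 4 `O=C(Nc1ccc(O)c(Sc2ncn[nH]2)c1)c1ccc([N+](=O)[O-])cc1` differs from compound 1 by 1H-1,2,4-triazol-5-yl in place of 1,3,4-thiadiazol-2-yl on a sulfur. No measured step covers this exchange; the one measured step also altered the group on the sulfur, but in the other series and toward 1,3,4-thiadiazol-2-yl, where compound 3 reached only 14.9%. With compound 1 reported as "not active" (no number reported) and carrying no number, compound 4 is expected to stay low, with no step beyond the scatter. Compound 4 is therefore estimated at about 10%, between 0% and 30%.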

Compound 4, a percentage reported as inhibition, at one concentration (the size of the read-out at that concentration, not a potency): 50.7%
Compound 4: the middle estimate sits 40.7 percentage points below what was measured, and the stated range ends below it.
By their numbers in this assay, from the lowest: compound 3; then compound 2; then compound 4.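

In this assay compound 1 is recorded as "not active" (no number reported) and compound 4 gives 50.7% and no step can be read between them. The compounds shown leave open how much 1H-1,2,4-triazol-5-yl changes inhibition relative to 1,3,4-thiadiazol-2-yl. No measurement here bears on this result.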